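The source may report more compounds than this note shows. Statements on the series, on what has been measured and on what is new or still open speak of the compounds shown alone.

Measured in a functional assay on MDA-MB-231 cells (Homo sapiens) for antiproliferative activity, read by MTT assay, with a stated time of 72 h; a lower number here means a stronger inhibitor, a higher number a weaker inhibitor:
- compound 1 `O=C(NO)c1ccc(NCCOc2ccc3cc2COC/C=C/COCc2cccc(c2)-c2ccnc(n2)N3)cc1`: 8690 nM
- compound 2 `O=C(O)CCCCCCCOc1ccc2cc1COC/C=C/COCc1cccc(c1)-c1ccnc(n1)N2`: 17100 nM

For the measured compounds named here, compound 2, at 17100 nM, lies within the scatter of compound 1, and the only measured step is a 2.0-fold higher number from compound 1 to compound 2 (0.29 log units; within the scatter). Next comes compound 3 `O=C(O)CCCCCCOc1ccc2cc1COC/C=C/COCc1cccc(c1)-c1ccnc(n1)N2`, with the change (carboxy in place of carboxymethyl on a saturated chain carbon, six bonds along the chain from an oxygen on an aromatic ring). In words, this is carboxy in place of carboxymethyl on a saturated chain carbon, six bonds along the chain from an oxygen on an aromatic ring. Going by the values given here, no measured pair isolates this change, so the evidence is indirect. Among the compounds with values here, the one available step exchanges the whole end group, yet it amounts only to a 2.0-fold higher number from compound 1 to compound 2 (0.29 log units; within the scatter). In this assay, no shift beyond the scatter is therefore expected, and the expected step is a 1.1-fold lower number from compound 2 to compound 3 (0.03 log units; within the scatter). Compound 3 is estimated at 16000 nM, with an expected range of 8000 nM to 36000 nM.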

Compound 3, half-maximal inhibitory concentration: 12000 nM
Compound 3: the middle estimate sits 1.3-fold (0.12 log units) above what was measured; low and high end bracket the measured number.
By their numbers in this assay, from the lowest: compounds 1, 3 and 2 (each within the scatter of the next).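

Carboxy in place of carboxymethyl, six bonds along the chain from an oxygen on an aromatic ring, gives a 1.4-fold lower number from compound 2 to compound 3 (0.15 log units; within the scatter) in this assay and so leaves no readable effect of this chain change on the carboxylic acid series. Set against the hydroxamic acid end group, 4-carboxybutyl in place of (4-(hydroxycarbamoyl)phenyl)amino gives a 1.4-fold higher number from compound 1 to compound 3 (0.14 log units; within the scatter) as its step, so a second acid-ended chain also stays within the scatter of compound 1. No measurement on hand bears on the reason for these small steps.

All three compounds sit within the scatter of one another, so no end group or chain length here is separated from another. Going by these compounds, whether a primary amine or a methyl ester at the chain end, or a hydroxamic acid on a plain saturated chain, would shift the number beyond the scatter remains open.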